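The source may report more compounds than this note shows. Statements on the series, on what has been measured and on what is new or still open speak of the compounds shown alone.

Measured compounds:
compound 1 `COc1ccc(C(=O)O[C@@H]2[C@H](OC(=O)c3ccc(OC)cc3)[C@@H](COP(=O)(O)OP(=O)(O)OP(=O)(O)O)O[C@H]2n2cnc3c(N)ncnc32)cc1` — in an assay on CHO cells for agonist activity at P2X purinoceptor 2 (Homo sapiens), read by calcium flux, with stated times of 1 h and 30 min, in the presence of a further agent that is not named here (on this read-out lower numbers stand for stronger inhibition and higher numbers for weaker inhibition), compound 1 gives > 100000 nM
compound 2 `O=P(O)(O)OP(=O)(O)OP(=O)(O)OC[C@H]1O[C@@H](n2cnc3c(Nc4ccccc4)ncnc32)[C@H](O)[C@@H]1O` — in this assay compound 2 gives 3.72 nM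

The value of compound 1 is a limit of the assay and not a number, as the limit of > 100000 nM in this assay, at which 1 of the 2 values shown sits, records. Compound 2 therefore stands as the only number shown in this assay, with no other measured number to rank it against. Compound 3 `O=P(O)(O)OP(=O)(O)OP(=O)(O)OC[C@H]1O[C@@H](n2cnc3c(NCc4ccccc4)ncnc32)[C@H](O)[C@@H]1O` is not yet measured in this assay; it differs from compound 2 by benzyl in place of phenyl on a nitrogen on an aromatic ring. For the measured compounds named here, no step between measured compounds informs this change, so the expectation rests on compound 2 alone. The inserted methylene is expected to weaken activity modestly, a step of a 4.0-fold higher number from compound 2 to compound 3 (0.61 log units; beyond the scatter) that is expected to reach beyond the usual scatter but not by much. Compound 3 is estimated at 15 nM, within a range from 3 nM to 80 nM.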

Compound 3, half-maximal inhibitory concentration: 3980 nM
Estimate against measurement, compound 3: 270-fold (2.42 log units) below; the measured number lies above the stated range.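

The change on this nitrogen on an aromatic ring is far from minor: in this assay, benzyl in place of phenyl gives a 1100-fold higher number from compound 2 to compound 3 (3.03 log units; beyond the scatter), a large step. For the compounds shown here, this is the first step read at this position, and it shows that the number here responds strongly to a change as small as anilino to benzylamino, with benzyl carrying only one carbon more than phenyl. Nothing given here accounts for the size of this step.

The compounds shown leave open whether a longer chain such as phenethyl on the same nitrogen would raise the number further, and whether a smaller group such as methyl would do the same. They also leave open whether a phenyl ring carrying an amine or a carboxylic acid would keep the low number of compound 2.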